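This account rests on a few compounds, and the source may have more. Where it says the series, first, only, none or still open, it means among the compounds named here.

Compound 1 `ClCc1ccccc1Cn1cnc2c(Cl)nc(Cl)nc21` gives 4260 nM in a functional assay on SK-MEL-5 cells (Homo sapiens) for cytotoxicity, read by sulforhodamine B assay, with a stated time of 48 h; a lower number here means that less compound is tolerated, a higher number that more compound is tolerated.
Compound 2 `ClCc1ccccc1Cn1cnc2c(Cl)ncnc21` gives 5880 nM in this assay.
Compound 3 `ClCc1cccc(Cn2cnc3ncnc(Cl)c32)c1` gives 45700 nM in this assay.

Compound 2 and compound 1 share a core and differ in one place: chloro in place of hydrogen on an aromatic carbon. The step in this assay is a 1.4-fold lower number from compound 2 to compound 1 (0.14 log units; within the scatter), so these two compounds cannot be told apart by this measurement.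

Compound 3 has the same atoms as compound 2, joined differently; the difference between the two cores is not broken down here. In this assay compound 3 gives 45700 nM, the highest of the three numbers, and its distance from compound 2 and from compound 1 lies beyond the scatter, so more of compound 3 is tolerated by the cells than of either other compound.

Compound 4 `ClCc1cccc(Cn2cnc3nc(Cl)nc(Cl)c32)c1` has not yet been measured. It stands to compound 3 as compound 1 stands to compound 2: chloro in place of hydrogen on an aromatic carbon. Going by the values given here, this is the same change as the one from compound 2 to compound 1, made on the same kind of place, and that earlier step was a 1.4-fold lower number from compound 2 to compound 1 (0.14 log units; within the scatter). On this basis the expected step from compound 3 to compound 4 in this assay is a 1.3-fold lower number from compound 3 to compound 4 (0.12 log units; within the scatter), a small shift that rests on a single prior example. The estimate for compound 4 in this assay is therefore 35000 nM, expected to fall between 15000 nM and 80000 nM.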

Compound 4, concentration lethal to 50% of the cells: 4890 nM
The estimate for compound 4 lay 7.2-fold (0.85 log units) above the measured number; the measured number lies below the stated range.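

In this assay, putting chloro in place of hydrogen on an aromatic carbon, at the place between two ring nitrogen atoms, gives a 9.3-fold lower number from compound 3 to compound 4 (0.97 log units; beyond the scatter), a clear drop in the amount of compound the cells tolerate. The same change therefore did not carry over from one core to the other with the same size, and a step measured on one core was a poor guide to the step on the other: the same change on two cores in this assay, a 1.4-fold lower number (0.14 log units; within the scatter) from compound 2 to compound 1 and a 9.3-fold lower number (0.97 log units; beyond the scatter) from compound 3 to compound 4, 6.8-fold (0.83 log units) apart, beyond the scatter of two such steps. Going by these compounds alone, this shows that, in these two pairs, the result of adding this chloro depends on the core that carries it, but with only two pairs it cannot show why the steps differ, nor how large the step would be on any third core.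

The compounds shown leave open whether the large step belongs to chloro itself, since no other group at that place, such as an amine or a methoxy group, can be set beside it. They also leave open how much the chloromethyl group matters on either core, which a comparison with a plain methyl group or a hydroxymethyl group in its place could begin to answer.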